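Dimethylaminophenyl replaces methylthiophenyl in a thioether enone series

This account rests on a few compounds, and the source may have more. Where it says the series, first, only, none or still open, it means among the compounds named here.

Compound 1 `Cc1ccc(/C=C(/SCc2ccc(Cl)cc2Cl)C(=O)c2ccc(Cl)cc2)s1` is measured in a functional assay on DU-145 cells (Homo sapiens) for inhibition, read by trypan blue exclusion, with a stated time of 96 h (a lower number here means a stronger inhibitor of growth, a higher number a weaker inhibitor of growth), where compound 1 gives 50000 nM. Compound 2 `Cc1ccc(CS/C(=C/c2ccc(C)s2)C(=O)c2ccc(Cl)cc2)cc1` gives 50000 nM in this assay, and the step of no change at the digits printed from compound 1 to compound 2 (within the scatter) leaves compound 1 level with compound 2. Compound 3 `CN(C)c1ccc(/C=C(/SCc2ccc(Cl)cc2Cl)C(=O)c2ccc(Cl)cc2)cc1` differs from compound 1 by 4-(dimethylamino)phenyl in place of 5-methylthiophen-2-yl on a double-bonded chain carbon bound to a double-bonded chain carbon. Within the data shown here, the only measured step, no change at the digits printed from compound 1 to compound 2 (within the scatter), alters a different part of the molecule, so no step bears directly on this change. Compound 3 is therefore expected to give about 45000 nM, between 15000 nM and 100000 nM. The expected step is a 1.1-fold lower number from compound 1 to compound 3 (0.05 log units; within the scatter), none beyond the scatter.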

Compound 3, concentration for 50% growth inhibition: 50000 nM
Compound 3: the middle estimate sits 1.1-fold (0.05 log units) below what was measured; low and high end bracket the measured number.
By their numbers in this assay, from the lowest: compounds 1, 2 and 3 (each within the scatter of the next).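

At this place, on a double-bonded chain carbon bound to a double-bonded chain carbon, 4-(dimethylamino)phenyl in place of 5-methylthiophen-2-yl gives no change at the digits printed from compound 1 to compound 3 (within the scatter) in this assay. Among these compounds, this is the first reading at this place, since the earlier step changed only the group on a saturated chain carbon bound to a sulfur, and neither place has yet moved the number. Nothing given here accounts for this result.

Going by these compounds, whether a smaller group, such as a plain phenyl, or a carboxylic acid on that ring would move the number remains open. So does whether any group at either place gives a lower number than these three compounds share.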